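Open-chain amine in place of the piperidine ring

The source may hold more compounds than are shown below. What is called first, only, known or untested is meant among the compounds shown, and "the series" means these compounds.

Compound 1: `CC(C)C[C@H](N)CN(C(=O)[C@@H]1C[C@H]1c1ccccc1)c1ccc(-c2ccccc2)cc1` — 880 nM
Compound 2: `O=C([C@@H]1C[C@H]1c1ccccc1)N(CC1CCCNC1)c1ccc(-c2ccccc2)cc1` — 10 nM

Compound 2 holds the lowest number of the two compounds measured in a functional assay for agonist activity at G protein-coupled receptor 88 (Homo sapiens), read by HTRF and cAMP accumulation; a higher number here means that more compound is needed for the effect, a lower number that less compound is needed; its nearest neighbour is compound 1, which in this assay gives 880 nM. Compound 3, `CCC(CC)C(N)CCN(C(=O)[C@@H]1C[C@H]1c1ccccc1)c1ccc(-c2ccccc2)cc1`, has not yet been measured. It differs from compound 2 by the change (2-amino-3-ethylpentyl in place of piperidin-3-yl on a saturated chain carbon bound to an amide-type nitrogen). Among the compounds with values here, the only measured step that bears on this is an 88-fold lower number from compound 1 to compound 2 (1.94 log units; beyond the scatter), in which the open-chain primary amine of compound 1 was replaced by the ring amine. Compound 3 returns to an open-chain primary amine, so a step back in the direction of compound 1 is expected, though the chain is longer and branched differently, so the full size of that step is uncertain. The estimate for compound 3 is 250 nM, with a range of 60 nM to 1000 nM, corresponding to an expected step of a 25-fold higher number from compound 2 to compound 3 (1.40 log units; beyond the scatter).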

Compound 3, half-maximal effective concentration: 2 nM
For compound 3 the middle estimate is 130-fold (2.10 log units) above the measured one, outside the stated range (below it).
By their numbers in this assay, from the lowest: compound 3; then compound 2; then compound 1.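

In this assay, a ring is not required at this place on a saturated chain carbon bound to an amide-type nitrogen: replacing piperidin-3-yl with the open-chain 2-amino-3-ethylpentyl gives a 5.0-fold lower number from compound 2 to compound 3 (0.70 log units; beyond the scatter). The high number of compound 1 therefore does not follow from an open-chain amine as such, and the two open chains are far apart, with a 440-fold lower number from compound 1 to compound 3 (2.64 log units; beyond the scatter). No measurement shown here explains these steps.

Compound 1 and compound 3 differ in both chain length and branching, so the contribution of each remains unresolved. From the compounds shown here alone, it also remains open whether the primary amine of compound 3 could give way to a methylamine or a hydroxyl group on the same 3-ethylpentyl chain without losing the low number.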